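Compound 4 in the series: a further limit expected?

The compounds below may be only part of what the source reports. "The series", "measured", "known", "first", "only" and "open" are said of these compounds alone.

Measured in a functional assay on HCT-116 cells (Homo sapiens) for antiproliferative activity, read by MTT assay, with a stated time of 24 h; on this read-out higher numbers stand for weaker inhibition and lower numbers for stronger inhibition:
Compound 1 `COc1cccc(/C=C/C(=O)c2ccc(OC)c3c2OC(C)(C)C=C3)c1`: > 10000 nM (a limit)
Compound 2 `COc1ccc(/C=C/C(=O)c2ccc(OC)c3c2OC(C)(C)C=C3)c(F)c1`: > 10000 nM (a limit)
Compound 3 `COc1ccc(C(=O)/C=C/c2ccsc2)c2c1C=CC(C)(C)O2`: > 10000 nM (a limit)

Compound 3 stands only at a limit, > 10000 nM, and no number is available for it. The two other compounds also give limits, so no order can be read among the three.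

The next compound is compound 4 `COc1ccc(C(=O)/C=C/c2cccc(Cl)c2)c2c1C=CC(C)(C)O2`. Its structural change from compound 3 is 3-chlorophenyl in place of thiophen-3-yl on a double-bonded chain carbon bound to a double-bonded chain carbon.

Two measured changes touch the same place: a step that the two limits leave unreadable from compound 1 to compound 3, and a step that the two limits leave unreadable from compound 2 to compound 3. The remaining one, a step that the two limits leave unreadable from compound 1 to compound 2, concerns the same place as well. None of the three has a readable size, so none gives a direction for the change to 3-chlorophenyl. The closest group in the measured set is the 3-methoxyphenyl of compound 1, which also gives a limit, > 10000 nM.

In this assay, within the data shown here, no clear gain or loss is expected, because the limit of > 10000 nM in this assay, at which 3 of the 3 values shown sit, offers no measured step to build on. A further limit is the likeliest report, although a measurable value cannot be excluded. The expected change is a step that the limit leaves unreadable from compound 3 to compound 4. For compound 4 the estimated value is 13000 nM. The expected range for compound 4 runs from 4000 nM to 30000 nM.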

Compound 4, half-maximal inhibitory concentration: > 10000 nM
Compound 4 was reported as a limit; the forecaster's own chance of this, stated with the estimate: 70%; the middle value does not contradict the limit.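

In this assay compound 4 is reported only as a limit, so no step between compound 4 and compound 1, compound 2 or compound 3 can be read: the limit of > 10000 nM in this assay, at which 4 of the 4 values shown sit.

The compounds shown leave open whether any group at this place on the shared core gives a measurable value, and how these groups rank against one another.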